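Dropping the chloro substituent: compound 3 expected to hold level

A few compounds are considered here, and "the series" means these few. Any claim that something is new, unique, unknown or untested is made for them only; others in the source may bear on it.

Measured so far:
compound 1, `O=C(/C=C/c1cccc([N+](=O)[O-])c1)c1ccc2ccccc2c1`, 11000 nM
compound 2, `O=C(/C=C/c1cccc(Cl)c1)c1ccc2ccccc2c1`, 11000 nM

In a functional assay on CCRF-CEM cells (Homo sapiens) for cytotoxicity, read by MTT assay, with a stated time of 24 h (on this read-out lower numbers stand for stronger inhibition and higher numbers for weaker inhibition), compound 1 gives 11000 nM. In this assay compound 2 gives 11000 nM. Within the data shown here, the one measured step, no change at the digits printed from compound 1 to compound 2 (within the scatter), is a swap of chloro in place of nitro on an aromatic carbon, and it left the read-out where it was. Compound 2 therefore stands level with compound 1 on the numbers shown, with no gap beyond the scatter between them.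

Compound 3, `O=C(/C=C/c1ccccc1)c1ccc2ccccc2c1`, differs from compound 2 by hydrogen in place of chloro on an aromatic carbon. Among the measured compounds shown here, the only step that bears on this is no change at the digits printed from compound 1 to compound 2 (within the scatter), which exchanged one group for another at this position without moving the value; no measured step removes the group altogether. Given that the two groups tried at this carbon gave the same outcome, the step of no change at the digits printed from compound 2 to compound 3 (within the scatter) is expected to be none beyond the scatter. Compound 3 is accordingly estimated at 11000 nM, with a range from 5000 nM to 25000 nM.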

Compound 3, half-maximal inhibitory concentration: 12000 nM
Estimate against measurement, compound 3: 1.1-fold (0.04 log units) below, within the range that was stated.
By their numbers in this assay, from the lowest: compounds 1, 2 and 3 (each within the scatter of the next).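

Removing the substituent outright is what the earlier pair could not test: in this assay the exchange of chloro for hydrogen is a 1.1-fold higher number from compound 2 to compound 3 (0.04 log units; within the scatter) and the exchange of nitro for hydrogen on the same aromatic carbon is a 1.1-fold higher number from compound 1 to compound 3 (0.04 log units; within the scatter) with the shared core unchanged. Among these compounds, the earlier compounds showed only that one group could take the place of another at this carbon, whereas the plain phenyl now stands within the scatter of both substituted compounds. Among these three compounds, then, neither the chloro nor the nitro group is needed to hold the read-out where it stands, and no compound of the three stands apart from the others.

Going by these compounds, whether an amine, a carboxylic acid or a longer chain on this carbon would move the number away from this level remains open, as does whether the carbon would stay as unresponsive with a different core. Nothing available speaks to why the read-out stays level across these three groups.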